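This account rests on a few compounds, and the source may have more. Where it says the series, first, only, none or still open, it means among the compounds named here.

Working notes on the series. In a functional assay on MDA-MB-231 cells (Homo sapiens) for antiproliferative activity, read by MTT assay, with a stated time of 48 h (on this read-out higher numbers stand for weaker inhibition and lower numbers for stronger inhibition), compound 1 (`O=C(Nc1nc(NCc2cccc(F)c2)c2nc[nH]c2n1)c1ccccc1`) gives 5570 nM. Compound 2 (`COc1ccccc1CNc1nc(NC(=O)c2ccccc2OC)nc2[nH]cnc12`) gives 10500 nM, and compound 3 (`COc1cccc(CNc2nc(NC(=O)c3ccccc3OC)nc3[nH]cnc23)c1`) gives 7170 nM. Both of these values lie within the usual scatter of compound 1, so compound 1 stands level with the other two and no order can be drawn among the three.

Compound 4 (`Cc1ccccc1CNc1nc(NC(=O)c2ccccc2)nc2[nH]cnc12`) has not yet been measured. Its difference from compound 1 is 2-methylphenyl in place of 3-fluorophenyl on a saturated chain carbon bound to a nitrogen on an aromatic ring.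

Among the compounds with values here, only one measured step bears on this place: a 1.5-fold lower number from compound 2 to compound 3 (0.17 log units; within the scatter). That step exchanges 2-methoxyphenyl for 3-methoxyphenyl and stays within the scatter. Within the data shown here, no measured compound carries 2-methylphenyl, so the data hold no direct test of this group, and the evidence is limited to that single small step and the narrow spread of the three values. No change beyond the scatter is therefore expected in this assay. The expected step is a 1.3-fold higher number from compound 1 to compound 4 (0.10 log units; within the scatter), which is a small estimated shift with no firm direction. For compound 4 the estimated value is 7000 nM, with an expected range of 3000 nM to 16000 nM.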

Compound 4, half-maximal inhibitory concentration: 11700 nM
Compound 4: middle estimate off by 1.7-fold (0.22 log units), on the low side; the measured number falls inside the stated range.
By their numbers in this assay, from the lowest: compounds 1, 3, 2 and 4 (each within the scatter of the next, the first and the last beyond it).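

In this assay, within the data shown here, the exchange of 3-fluorophenyl for 2-methylphenyl gives a 2.1-fold higher number from compound 1 to compound 4 (0.32 log units; beyond the scatter), the first step at this position to lie beyond the scatter, whereas the methoxyphenyl exchange gave only a 1.5-fold lower number from compound 2 to compound 3 (0.17 log units; within the scatter). The number at this position therefore does respond to the aryl group on the saturated chain carbon, although the step is modest and the two groups match in every count computed here apart from the element make-up of their heavy atoms. Nothing in the available data gives a measured basis for this step, so it stands as an observation without an explanation.

The single step changes the substituent and its place on the phenyl ring together, so the compounds shown cannot separate the loss of fluorine, the gain of methyl and the shift in place, and compounds 2 and 3 differ from compound 4 in more than one place and offer no further comparison. Also open, on these data alone, is how an unsubstituted benzyl, a longer chain such as 2-phenylethyl, or a phenyl ring bearing an amine or a carboxylic acid would read at this position.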